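This account rests on a few compounds, and the source may have more. Where it says the series, first, only, none or still open, it means among the compounds named here.

Among the compounds with values here, compound 2 `COC(=O)[C@H](NC(=O)Cn1cc(C2=C(c3c[nH]c4ccccc34)C(=O)N(C)C2=O)c2ccccc21)[C@@H](C)O` is the one compound here with a number rather than a limit: in a functional assay on MCF7 cells (Homo sapiens) for cytotoxicity, read by MTT assay, with a stated time of 24 h (a higher number here means a weaker inhibitor, a lower number a stronger inhibitor), compound 2 gives 22900 nM. Compound 1 `CC[C@H](C)[C@@H](NC(=O)Cn1cc(C2=C(c3c[nH]c4ccccc34)C(=O)N(C)C2=O)c2ccccc21)C(=O)OC` differs from it by an ethyl where compound 2 carries a hydroxy, and in this assay compound 1 gives only a limit, > 100000 nM. The step of an at least 4.3-fold lower number from compound 1 to compound 2 (0.64 log units; beyond the scatter) is therefore known only as a lower bound, because the limit of > 100000 nM in this assay, at which 1 of the 2 values shown sits, caps it. Compound 3 `COC(=O)[C@@H](C)NC(=O)Cn1cc(C2=C(c3c[nH]c4ccccc34)C(=O)N(C)C2=O)c2ccccc21` has not been measured. It differs from compound 2 by methyl in place of 1-hydroxyethyl on a saturated chain carbon bound to an amide-type nitrogen and a carbonyl carbon. Within the data shown here, the single measured step bears on it in reverse: the step of an at least 4.3-fold lower number from compound 1 to compound 2 (0.64 log units; beyond the scatter) came with the arrival of the hydroxy, and compound 3 loses that hydroxy again along with the rest of the 1-hydroxyethyl. The expected step is accordingly an increase, a 2.2-fold higher number from compound 2 to compound 3 (0.34 log units; beyond the scatter), though the measured pair does not mirror the change exactly. Compound 3 is estimated at 50000 nM in this assay, within 20000 nM to 150000 nM.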

Compound 3, half-maximal inhibitory concentration: 15300 nM
Beside the measured number, compound 3's estimate is 3.3-fold (0.51 log units) above it; the whole stated range lies above it.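

In this assay, methyl in place of 1-hydroxyethyl on a saturated chain carbon bound to an amide-type nitrogen and a carbonyl carbon gives a 1.5-fold lower number from compound 2 to compound 3 (0.18 log units; within the scatter), so the hydroxy is not needed for the number seen with compound 2. Methyl in place of sec-butyl at the same place gives an at least 6.5-fold lower number from compound 1 to compound 3 (0.81 log units; beyond the scatter), which shows that compound 3, without any hydroxy, also stands clear of compound 1. This step is only a bound, as the value of compound 1 is a limit: the limit of > 100000 nM in this assay, at which 1 of the 3 values shown sits.

The compounds shown leave open where between methyl and sec-butyl the number rises beyond that limit. They also leave open how an amine or a longer chain at this place, or a carboxylic acid in place of the methyl ester, would read.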